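The source may report more compounds than this note shows. Statements on the series, on what has been measured and on what is new or still open speak of the compounds shown alone.

Values measured in an ADME assay on CCRF-CEM cells (Homo sapiens) for cytotoxicity, with a stated time of 5 days (a higher number here means a weaker inhibitor, a lower number a stronger inhibitor), so far

Compound 1 (`C=CCNc1nc(N)nc2c1ncn2[C@H]1C[C@H](N=[N+]=[N-])[C@@H](CO)O1`) gives > 100000 nM as a limit.
Compound 2 (`CNc1nc(Cl)nc2c1ncn2[C@H]1C[C@H](N=[N+]=[N-])[C@@H](CO)O1`) gives > 100000 nM as a limit.
Compound 3 (`CC(CO)Nc1nc(N)nc2c1ncn2[C@H]1C[C@H](N=[N+]=[N-])[C@@H](CO)O1`) gives > 100000 nM as a limit.

Compound 2 therefore offers no number to step from, and it stands with the rest of the series at the limit of > 100000 nM in this assay, at which 3 of the 3 values shown sit, in the measurements so far. Compound 4 (`[N-]=[N+]=N[C@H]1C[C@H](n2cnc3c(N)nc(Cl)nc32)O[C@@H]1CO`) differs from it by hydrogen in place of methyl on a nitrogen on an aromatic ring and so carries hydrogen in place of methyl on a nitrogen on an aromatic ring. Among the measured compounds shown here, the one measured step at a nitrogen of this kind is a step that the two limits leave unreadable from compound 1 to compound 3 and gives no size to carry over. It also involves a different exchange. For the measured compounds named here, no step of readable size can therefore be expected in this assay, and no direction can be assigned. The estimate for a number no higher from compound 2 to compound 4 (the limit leaves the size open) is accordingly no more than a placeholder with a wide margin. Compound 4 is expected to read about 100000 nM on this estimate, within an estimated range of 30000 nM to 300000 nM and quite possibly as a limit again.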

Compound 4, half-maximal inhibitory concentration: > 100000 nM
Compound 4: a limit, no number; the forecaster's own chance of this, stated with the estimate: 75%; the middle value sits exactly at the limit.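

Among the compounds shown here, compound 2 and compound 4 both read only as limits in this assay and the change from methylamino to amino therefore gives no step that can be read. The compounds shown leave open whether any change on the shared core gives a measurable value, and in which direction it would move.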